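Ring fluorination on the cyclohexyl amide of compound 1

The source may hold more compounds than are shown below. What is called first, only, known or untested is meant among the compounds shown, and "the series" means these compounds.

Measured compounds:
compound 1 `O=C(C1CCCCC1)N1CC(c2nc(-c3cccc(F)c3)no2)C1` — 1000 nM
compound 2 `O=C(C1CCC(C(F)(F)F)CC1)N1CC(c2nc(-c3cccc(F)c3)no2)C1` — 680 nM
compound 3 `O=S(=O)(c1ccc(F)cc1)N1CC(c2nc(-c3cccc(Cl)c3)no2)C1` — > 10000 nM

Of the compounds shown here, three have been tested in an assay on HEK293 cells for positive allosteric modulation of metabotropic glutamate receptor 5 (Homo sapiens), read by FLIPR; on this read-out higher numbers stand for an effect only at larger amounts of compound and lower numbers for an effect already at smaller amounts. Compound 1 gives 1000 nM. Compound 2, which carries trifluoromethyl in place of hydrogen on a saturated ring carbon, gives 680 nM, and the step is a 1.5-fold lower number from compound 1 to compound 2 (0.17 log units; within the scatter). Compound 3 returns only a limit, > 10000 nM, which is not a number. Compound 1 and compound 2 therefore sit within the scatter of each other, and compound 3 offers no number to set beside them.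

Compound 4 `O=C(C1CCC(F)(F)CC1)N1CC(c2nc(-c3cccc(F)c3)no2)C1` has not yet been measured. It differs from compound 1 in one place: 4,4-difluorocyclohexyl in place of cyclohexyl on a carbonyl carbon. Within the data shown here, the one measured step that bears on this change is a 1.5-fold lower number from compound 1 to compound 2 (0.17 log units; within the scatter), in which fluorine entered the same cyclohexyl ring without moving the number beyond the scatter. On that basis no step beyond the scatter is expected for compound 4 in this assay, in either direction. Compound 4 is accordingly estimated to give 800 nM, with a range from 300 nM to 2500 nM. The expected step is a 1.3-fold lower number from compound 1 to compound 4 (0.10 log units; within the scatter).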

Compound 4, half-maximal effective concentration: 520 nM
Beside the measured number, compound 4's estimate is 1.5-fold (0.19 log units) above it; the measured number falls inside the stated range.
By their numbers in this assay, from the lowest: compounds 4, 2 and 1 (each within the scatter of the next). At a limit, above all of these: compound 3.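

In this assay, 4,4-difluorocyclohexyl in place of cyclohexyl on a carbonyl carbon gives a 1.9-fold lower number from compound 1 to compound 4 (0.28 log units; within the scatter), and the earlier trifluoromethyl change gives a 1.5-fold lower number from compound 1 to compound 2 (0.17 log units; within the scatter), so this place has now taken two different fluorinated groups. Among these compounds, neither step leaves the scatter, which means that the one measured change at this place is no longer alone in that respect. Nothing at hand offers a reason for this result, and the one limit shown, which belongs to another compound, does not bear on it.

The compounds shown leave open whether an amine or a carboxylic acid on the cyclohexyl ring, or a longer chain in its place, would give a step beyond the scatter. On these data alone, a single fluorine or a hydroxyl on that ring remains equally open.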